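The source may hold more compounds than are shown below. What is called first, only, known or untested is meant among the compounds shown, and "the series" means these compounds.

Compound 1 `CN1CCN(CCCCCCn2c3c(c4ccccc42)C(=O)c2c[n+]([O-])c4ccccc4c2C3=O)CC1` and compound 2 `CN1CCN(CCCCCn2c3c(c4ccccc42)C(=O)c2c[n+]([O-])c4ccccc4c2C3=O)CC1` share a core with compound 3 `O=C1c2c[n+]([O-])c3ccccc3c2C(=O)c2c1c1ccccc1n2Cc1cn([C@H]2C[C@H](O)[C@@H](CO)O2)nn1`, and all three were measured in a toxicity assay on L02 cells (Homo sapiens) for cytotoxicity, read by MTT assay, with a stated time of 72 h; a higher number here means a weaker inhibitor, a lower number a stronger inhibitor. Compound 1 gives 3800 nM, compound 2 gives 1640 nM, and compound 3 gives 280 nM, the lowest number of the three. For the measured compounds named here, the one measured step, a 2.3-fold lower number from compound 1 to compound 2 (0.36 log units; beyond the scatter), concerns a chain at the other end of the molecule and so does not bear directly on what follows. Compound 4 `O=C1c2c[n+]([O-])c3ccccc3c2C(=O)c2c1c1ccccc1n2Cc1cn(C[C@@H](O)CO)nn1` differs from compound 3 by 2,3-dihydroxypropyl in place of 4-hydroxy-5-(hydroxymethyl)oxolan-2-yl on an aromatic nitrogen. Going by the values given here, with no measured step on this part of the structure, only a modest shift is expected, a 1.8-fold higher number from compound 3 to compound 4 (0.25 log units; within the scatter), most likely toward a higher number. Compound 4 is therefore estimated at 500 nM, between 150 nM and 1600 nM.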

Compound 4, half-maximal inhibitory concentration: 490 nM
Compound 4: the middle estimate sits 1.0-fold (0.01 log units) above what was measured; the measured number falls inside the stated range.
By their numbers in this assay, from the lowest: compounds 3 and 4 (each within the scatter of the next); then compound 2; then compound 1.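

In this assay, putting the ringless 2,3-dihydroxypropyl on this aromatic nitrogen in place of the ring-bearing 4-hydroxy-5-(hydroxymethyl)oxolan-2-yl gives (a 1.8-fold higher number from compound 3 to compound 4 (0.24 log units; within the scatter)), so the five-membered ring is not needed to keep the number in this range. Compound 4 also keeps its distance from the methylpiperazine chains, with (a 3.3-fold lower number from compound 2 to compound 4 (0.52 log units; beyond the scatter)) and (a 7.8-fold lower number from compound 1 to compound 4 (0.89 log units; beyond the scatter)), so the low number does not depend on the oxolane group alone. Nothing available explains these differences. On these data alone, whether the hydroxyl groups matter stays open, and a plain propyl chain or an amine on the same aromatic nitrogen would address that.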